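Anilinoquinoline series: halogen pattern on the aniline ring

A few compounds are considered here, and "the series" means these few. Any claim that something is new, unique, unknown or untested is made for them only; others in the source may bear on it.

Measured compounds:
compound 1 `CN1CCN(CCCOc2cccc3nc(Nc4ccc(Cl)c(C(F)(F)F)c4)ccc23)CC1` — 2000 nM
compound 2 `CN1CCN(CCCOc2cccc3nc(Nc4ccc(Cl)c(F)c4)ccc23)CC1` — 2120 nM
compound 3 `CN1CCN(CCCOc2cccc3nc(Nc4ccc(F)c(F)c4)ccc23)CC1` — 4730 nM

All three share one core and differ only in the substituents on the aniline ring. In a functional assay on Hs-578T cells (Homo sapiens) for inhibition, read by sulforhodamine B assay, with a stated time of 48 h (a higher number here means a weaker inhibitor of growth, a lower number a stronger inhibitor of growth), compound 3 gives the highest number of the three: the two steps that lead to it are a 2.2-fold higher number from compound 2 to compound 3 (0.35 log units; beyond the scatter) and a 2.4-fold higher number from compound 1 to compound 3 (0.37 log units; beyond the scatter), both beyond the scatter. Compound 1 and compound 2 sit within the scatter of each other, a 1.1-fold higher number from compound 1 to compound 2 (0.03 log units; within the scatter).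

Compound 4 `CN1CCN(CCCOc2cccc3nc(Nc4cccc(Cl)c4)ccc23)CC1` is not yet measured. The change from compound 3 is 3-chlorophenyl in place of 3,4-difluorophenyl on a nitrogen on an aromatic ring. Among the measured compounds shown here, two measured steps bear on it. The step from compound 2 to compound 3 exchanges chloro for fluoro at one position and gives a 2.2-fold higher number from compound 2 to compound 3 (0.35 log units; beyond the scatter); reversing that direction, fluoro back to chloro, should therefore give a lower number. The step from compound 1 to compound 3 removes both chloro and trifluoromethyl and gives a 2.4-fold higher number from compound 1 to compound 3 (0.37 log units; beyond the scatter). For the measured compounds named here, nothing among the measured compounds shows what removing the second substituent altogether does. The expectation for compound 4 is thus a modest step down in this assay, a 1.9-fold lower number from compound 3 to compound 4 (0.28 log units; within the scatter), landing near the value of compound 2. The estimate for compound 4 is 2500 nM, with a range of 1200 nM to 5200 nM.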

Compound 4, concentration for 50% growth inhibition: 1830 nM
Compound 4: middle estimate off by 1.4-fold (0.14 log units), on the high side; low and high end bracket the measured number.
By their numbers in this assay, from the lowest: compounds 4, 1 and 2 (each within the scatter of the next); then compound 3.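

In this assay, the 3-chlorophenyl group on the nitrogen gives a clear gain over 3,4-difluorophenyl (a 2.6-fold lower number from compound 3 to compound 4 (0.41 log units; beyond the scatter)), so a second ring substituent is not needed to reach the better range of this small set. Compound 4 cannot be told apart from the two disubstituted rings that carry chloro (a 1.2-fold lower number from compound 2 to compound 4 (0.06 log units; within the scatter); a 1.1-fold lower number from compound 1 to compound 4 (0.04 log units; within the scatter)), although its single chloro stands under a different number in the group name than the chloro of 4-chloro-3-fluorophenyl and 4-chloro-3-(trifluoromethyl)phenyl. Among the four compounds, all three rings with a chloro group lie within the scatter of one another, and compound 3, the only ring without chloro, stands apart with no compound going against this. Nothing measured here accounts for this pattern.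

Going by these compounds, it remains open whether chloro itself matters or any single substituent would serve, a question that plain phenyl, 3-fluorophenyl and 3-bromophenyl on the same nitrogen would address. The separate contribution of the chloro position also remains unresolved, and 4-chlorophenyl would bear directly on it.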